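Moving a Fluorine Where Both Anchors Sit at a Limit

The source may hold more compounds than are shown below. What is called first, only, known or untested is meant among the compounds shown, and "the series" means these compounds.

Compounds measured so far:
compound 1, `Cc1ccc(S(=O)(=O)Nc2ccc(NS(=O)(=O)c3ccc(F)cc3)cc2)cc1`: > 100000 nM in an assay for inhibition of liver carboxylesterase 1 (Homo sapiens), read by spectrophotometry; on this read-out higher numbers stand for weaker inhibition and lower numbers for stronger inhibition
compound 2, `Cc1ccc(S(=O)(=O)Nc2ccc(NS(=O)(=O)c3cc(F)ccc3F)cc2)cc1`: > 100000 nM in this assay

Compound 2 reaches only a limit in this assay, > 100000 nM, and not a number. Compound 1 likewise stops at a limit, > 100000 nM. The step that the two limits leave unreadable from compound 1 to compound 2 is therefore not readable in size. Compound 3, `Cc1ccc(S(=O)(=O)Nc2ccc(NS(=O)(=O)c3ccc(F)cc3F)cc2)cc1`, differs from compound 2 by 2,4-difluorophenyl in place of 2,5-difluorophenyl on a sulfonyl sulfur. Going by the values given here, no measured step reads on this change. Both anchors rest at the limit given by the limit of > 100000 nM in this assay, at which 2 of the 2 values shown sit, and compound 3 is expected to rest there as well. Compound 3 is estimated at 150000 nM, between 40000 nM and 600000 nM. This corresponds to an expected step that the limit leaves unreadable from compound 2 to compound 3.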

Compound 3, inhibition constant: > 100000 nM
Compound 3: only a limit was reported; the forecaster's own chance of this, stated with the estimate: 85%; the middle value is on the limit's open side.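

Compound 3 also gives only a limit, > 100000 nM, so no step among compound 1, compound 2 and compound 3 can be read: the limit of > 100000 nM in this assay, at which 3 of the 3 values shown sit.

The compounds shown leave open whether any fluorine arrangement on this phenyl group gives a numerical inhibition constant in this assay.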